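The source may hold more compounds than are shown below. What is called first, only, known or untested is meant among the compounds shown, and "the series" means these compounds.

Working notes on the series.

Compound 1 `CCNC(=O)c1oc2nc(-c3ccccc3)cc(C(F)(F)F)c2c1N` gives 70000 nM in an ADME assay on HEK293 cells (Homo sapiens) for antiproliferative activity, read by MTT assay; on this read-out higher numbers stand for weaker inhibition and lower numbers for stronger inhibition. Going by the values given here, compound 2 `Nc1c(C(=O)N/N=C/c2ccccc2)oc2nc(-c3ccccc3)cc(C(F)(F)F)c12` gives 70000 nM in this assay; the one measured step, no change at the digits printed from compound 1 to compound 2 (within the scatter), is flat. Compound 3 `Cc1ccc(/C=N/NC(=O)c2oc3nc(-c4cccs4)cc(C(F)(F)F)c3c2N)cc1` gives 78000 nM in this assay, the highest of the three numbers, but both others lie within the scatter of it, so no order among the three can be read.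

Compound 4 `Nc1c(C(=O)N/N=C/c2ccccc2)oc2nc(-c3cccs3)cc(C(F)(F)F)c12` is not yet measured in this assay. Its change from compound 3 is hydrogen in place of methyl on an aromatic carbon. Among the compounds with values here, no measured step removes a methyl from this ring; the only step available, no change at the digits printed from compound 1 to compound 2 (within the scatter), sits on the amide-type nitrogen and showed nothing beyond the scatter. Compound 2 and compound 4 share the same substituent on that ring, while compound 2 and compound 3 differ in two places and their values fall within the scatter of each other. On this basis the step of a 1.0-fold lower number from compound 3 to compound 4 (0.02 log units; within the scatter) is expected to stay within the scatter. Compound 4 is expected at 75000 nM, with a range of 40000 nM to 140000 nM.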

Compound 4, half-maximal inhibitory concentration: 72000 nM
Beside the measured number, compound 4's estimate is 1.0-fold (0.02 log units) above it; measured number inside the range.
By their numbers in this assay, from the lowest: compounds 1, 2, 4 and 3 (each within the scatter of the next).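

In this assay, going by these compounds alone, the methyl para to a large group can now be read for the first time: the change from 4-methylphenyl to phenyl gives a 1.1-fold lower number from compound 3 to compound 4 (0.03 log units; within the scatter) and leaves the number flat. Within the data shown here, the aromatic group on the core can also be read for the first time, since thiophen-2-yl in place of phenyl gives a 1.0-fold higher number from compound 2 to compound 4 (0.01 log units; within the scatter), which is also flat. Neither place, nor the amide-type nitrogen before them, has yet produced a step beyond the scatter, and no measurement offered here accounts for this.

From the compounds shown here alone, whether an amine or a carboxylic acid at the para place, or a longer chain in place of the methyl, would give a step beyond the scatter stays open. So does the effect of replacing the trifluoromethyl group or the free amine on the core.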